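This account rests on a few compounds, and the source may have more. Where it says the series, first, only, none or still open, it means among the compounds named here.

Measured so far in an ADME assay on MT4 cells (Homo sapiens) for cytotoxicity; on this read-out higher numbers stand for lower toxicity in this test and lower numbers for higher toxicity in this test:
Compound 1 `Cc1cc(C)cc(Cn2c(SCC(=O)Nc3ccccc3Br)nc3ccccc32)c1` gives >= 143000 nM as a limit of the assay, not a number
Compound 2 `Cc1cc(C)cc(Cn2c(SCC(=O)Nc3ccc(S(C)(=O)=O)cc3Cl)nc3ccccc32)c1` gives 106000 nM as a true number

Within the data shown here, compound 2 holds the only true number so far, and the one other reading is a limit. The next compound is compound 3 `Cc1cc(C)cc(Cn2c(SCC(=O)Nc3ccc(S(N)(=O)=O)cc3Cl)nc3ccccc32)c1` which differs from compound 2 in a single place (amino in place of methyl on a sulfonyl sulfur). This is amino in place of methyl on a sulfonyl sulfur, so methylsulfonyl becomes sulfamoyl.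

Among the measured compounds shown here, only one measured step bears on this, and only loosely. It placed 2-chloro-4-(methylsulfonyl)phenyl in the position of 2-bromophenyl on an amide-type nitrogen (an at least 1.3-fold lower number from compound 1 to compound 2 (0.13 log units; that floor lies within the scatter)). Its size is known from one side only because of the limit of >= 143000 nM in this assay, at which 1 of the 2 values shown sits, in the data. For the measured compounds named here, no measured pair changes the sulfonyl group itself.

Given compound 2 at 106000 nM after that wider swap, no step beyond the scatter is expected in this assay for this smaller change. The expected step is a 1.1-fold lower number from compound 2 to compound 3 (0.03 log units; within the scatter) and it remains uncertain. For compound 3 the estimated value is 100000 nM with an expected range from 40000 nM to 200000 nM as the likely span.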

Compound 3, half-maximal cytotoxic concentration: 111000 nM
The estimate for compound 3 lay 1.1-fold (0.05 log units) below the measured number, within the range that was stated.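

In this assay, among these compounds, the change from methylsulfonyl to sulfamoyl, with amino in place of methyl on a sulfonyl sulfur, gives a 1.0-fold higher number from compound 2 to compound 3 (0.02 log units; within the scatter); this is the first pair that changes the sulfonyl group alone, and even with the one hydrogen-bond donor that amino brings, this read-out does not separate the two groups. The wider swap, 2-chloro-4-sulfamoylphenyl in place of 2-bromophenyl on an amide-type nitrogen, gives an at least 1.2-fold lower number from compound 1 to compound 3 (0.11 log units; that floor lies within the scatter), much as the methylsulfonyl version did in the earlier step. Compound 1 gives a limit of the assay rather than a true number, so this wider step is known from one side only: the limit of >= 143000 nM in this assay, at which 1 of the 3 values shown sits.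

Still open, from the compounds shown here alone, is whether the flat result on the sulfonyl sulfur holds for something larger there, such as dimethylamino or a longer chain like propyl, rather than for these two small groups alone. It is also unknown how a carboxylic acid in place of the whole sulfonyl group would read in this assay, since both sulfonyl groups shown sit on the same 2-chlorophenyl frame.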